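Fluoro in Place of Methoxy: An Expected Small Step

A few compounds are considered here, and "the series" means these few. Any claim that something is new, unique, unknown or untested is made for them only; others in the source may bear on it.

Compound 1 `COc1ccc(-c2ccc(-c3ccc(C(=N)N)cc3)s2)cc1` and compound 2 `N=C(N)c1ccc(-c2ccc(-c3cc(Cl)cc(Cl)c3)s2)cc1` share a common core. In a functional assay on NCI/ADR-RES cells (Homo sapiens) for inhibition, read by sulforhodamine B assay, with a stated time of 48 h (on this read-out lower numbers stand for stronger inhibition of growth and higher numbers for weaker inhibition of growth), compound 1 gives 1490 nM, and compound 2 gives 1930 nM; these two values lie within the usual scatter of each other, so the two compounds cannot be told apart on this read-out. Compound 3 `N=C(N)c1ccc(-c2ccc(-c3ccc(F)cc3)s2)cc1` differs from compound 1 by fluoro in place of methoxy on an aromatic carbon. Within the data shown here, no measured pair shows how such an exchange moves this assay, so the direction is open; the expected step of a 1.2-fold higher number from compound 1 to compound 3 (0.08 log units; within the scatter) is small, likely no larger than the scatter. Compound 3 is expected to give about 1800 nM, within a range from 700 nM to 4500 nM.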

Compound 3, concentration for 50% growth inhibition: 1770 nM
For compound 3 the middle estimate is 1.0-fold (0.01 log units) above the measured one, and the stated range covers the measured number.
By their numbers in this assay, from the lowest: compounds 1, 3 and 2 (each within the scatter of the next).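

Fluoro in place of methoxy on an aromatic carbon, para to a large group, gives in this assay the first step measured at this position: a 1.2-fold higher number from compound 1 to compound 3 (0.07 log units; within the scatter). Methoxy and fluoro therefore cannot be told apart here, although fluoro brings one heavy atom in place of two. Nothing available bears on why the exchange leaves the number within the scatter.

The compounds shown leave open whether a different kind of group at this place, such as an amine or a carboxylic acid, would move the number beyond the scatter. They also leave open how a longer chain, such as butoxy, would behave there.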